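The source may report more compounds than this note shows. Statements on the series, on what has been measured and on what is new or still open speak of the compounds shown alone.

Measured compounds:
Compound 1 `COc1ccc(/C=N/Nc2nc(N)c3ncn([C@@H]4O[C@H](CO)[C@@H](O)[C@H]4O)c3n2)cn1` — in an assay on CHO-K1 cells for displacement of a labelled ligand from adenosine receptor A1 (Homo sapiens), read by scintillation counting, with a stated time of 60 min (a higher number here means a weaker inhibitor, a lower number a stronger inhibitor), compound 1 gives 2.6 nM.
Compound 3 `COc1cc(/C=N/Nc2nc(N)c3ncn([C@@H]4O[C@H](CO)[C@@H](O)[C@H]4O)c3n2)ccc1OCc1ccccc1` — in this assay compound 3 gives 9140 nM.
Compound 2 `Nc1nc(N/N=C/c2ccc(OCc3ccccc3)c(OCc3ccccc3)c2)nc2c1ncn2[C@@H]1O[C@H](CO)[C@@H](O)[C@H]1O` — in this assay compound 2 reaches only the limit of the assay, > 10000 nM, which is not a number.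

Compound 1 has the lowest of the two numbers that were obtained; the nearest, compound 3, sits far higher, well beyond the scatter. Among the compounds with values here, the one measured step, an at least 1.0-fold lower number from compound 2 to compound 3 (0.03 log units; that floor lies within the scatter), barely moves the number and concerns a benzyloxy group, not the part changed here. Note that (the limit of > 10000 nM in this assay, at which 1 of the 3 values shown sits).

Compound 4 `CN(C)c1ccc(/C=N/Nc2nc(N)c3ncn([C@@H]4O[C@H](CO)[C@@H](O)[C@H]4O)c3n2)cc1` differs from compound 1 in the group on the hydrazone carbon: 4-(dimethylamino)phenyl in place of 6-methoxypyridin-3-yl on a carbon with a double bond to nitrogen. Within the data shown here, no measured step touches this position. Both compounds carrying benzyloxy groups sit far weaker than compound 1, but compound 4 carries no such group, and the dimethylamino group entering is small, like the methoxy group that leaves. The expectation for compound 4 is therefore a modest step, a 3.1-fold higher number from compound 1 to compound 4 (0.49 log units; beyond the scatter), towards a somewhat higher number. Compound 4 is estimated at 8 nM, within 1.5 nM to 60 nM.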

Compound 4, inhibition constant: > 10000 nM
Compound 4 ended at the assay's limit; the forecaster's own chance of this, stated with the estimate: 3%; middle value at least 1200-fold (3.09 log units) from the limit.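

Swapping 6-methoxypyridin-3-yl for 4-(dimethylamino)phenyl on a carbon with a double bond to nitrogen gives an at least 3800-fold higher number from compound 1 to compound 4 (3.58 log units; beyond the scatter) in this assay, so a benzyloxy group is not needed for a very high number here. The swap changes two things at once, the ring and the group on it, and the result cannot separate them. Compound 4 gives > 10000 nM, which is a limit of the assay and not a number, so the true size of the step stays unknown: the limit of > 10000 nM in this assay, at which 2 of the 4 values shown sit.

The compounds shown leave open whether the low number of compound 1 depends on the ring nitrogen or on the methoxy group. A methoxyphenyl group, with a ring of carbon only, would help to separate these two parts of the change.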